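This account rests on a few compounds, and the source may have more. Where it says the series, first, only, none or still open, it means among the compounds named here.

Compound 2 `Cn1ccnc1Sc1cnc(N)nc1-c1ccccc1O` is the best tolerated of the three measured compounds in an ADME assay on MDCK cells (Canis lupus familiaris) for cytotoxicity (a higher number here means that more compound is tolerated, a lower number that less compound is tolerated), where compound 2 gives 388000 ug/mL. Compound 1 `COc1ccc(O)c(-c2nc(C(C)(C)C)ncc2Sc2nccn2C)c1` gives 116000 ug/mL, and compound 3 `Cn1ccnc1Sc1cnc(C(C)(C)C)nc1-c1cc(Cl)ccc1O` gives 111000 ug/mL, both clearly lower than compound 2 and beyond the scatter from it. Among the measured compounds shown here, the only step between compounds that differ in a single place is a 1.0-fold lower number from compound 1 to compound 3 (0.02 log units; within the scatter), and it concerns an exchange on the 2-hydroxyphenyl side of the molecule, not the place altered here.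

Compound 4 `Cn1ccnc1Sc1cnc(-c2ccc(N)cc2)nc1-c1ccccc1O` differs from compound 2 in one place: 4-aminophenyl in place of amino on an aromatic carbon. For the measured compounds named here, no measured step touches this place on the shared core, so the expectation rests on the values alone. Compound 1 and compound 3 carry a larger group than amino at the same place and both sit lower than compound 2, but they also differ from compound 2 elsewhere, so this is a hint and not a measured step. A larger substituent generally seems to go with a lower number in this set, and an aromatic ring is a considerable enlargement. The step of a 2.6-fold lower number from compound 2 to compound 4 (0.41 log units; beyond the scatter) is therefore the expected outcome, with a moderately lower number than compound 2. For compound 4 the estimated value is 150000 ug/mL, within a range from 50000 ug/mL to 400000 ug/mL.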

Compound 4, half-maximal cytotoxic concentration: 80100 ug/mL
Compound 4: the middle estimate sits 1.9-fold (0.27 log units) above what was measured; measured number inside the range.
By their numbers in this assay, from the lowest: compounds 4, 3 and 1 (each within the scatter of the next); then compound 2.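

In this assay, putting 4-aminophenyl in place of amino on the aromatic carbon between the two ring nitrogen atoms gives a 4.8-fold lower number from compound 2 to compound 4 (0.69 log units; beyond the scatter), the first step measured at this place on the shared core. Among the compounds shown here, this shows that the place is sensitive to what sits on it, since the step lies beyond the usual scatter, whereas the one earlier single-place step, a 1.0-fold lower number from compound 1 to compound 3 (0.02 log units; within the scatter), stayed within it and concerned another part of the molecule. The entering group adds one six-membered aromatic ring of carbon only and leaves the number of hydrogen-bond donors and acceptors as it was, but nothing available explains why the number falls.

Going by these compounds, what remains open is whether the lower number goes with the ring itself or with the amino group carried on it, which a plain phenyl group at this place would help to separate. On these data alone, it is also open whether any larger group does the same, and a methyl group or a saturated ring such as piperidine at this place would test that.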